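Adding an Amino Group to a Weak Purine-Type Inhibitor

This account rests on a few compounds, and the source may have more. Where it says the series, first, only, none or still open, it means among the compounds named here.

Compound 1 `ClCc1ccccc1Cn1cnc2c(Cl)nc(Cl)nc21` and compound 2 `ClCc1ccccc1Cn1cnc2c(Cl)ncnc21` share one core and were tested in a functional assay on NCI-H460 cells (Homo sapiens) for cytotoxicity, read by sulforhodamine B assay, with a stated time of 48 h; on this read-out lower numbers stand for stronger inhibition of growth and higher numbers for weaker inhibition of growth. In this assay compound 1 gives 3310 nM, and compound 2 gives 15500 nM. Within the data shown here, the only step known so far, a 4.7-fold higher number from compound 1 to compound 2 (0.67 log units; beyond the scatter), shows that removing the chloro at that position on the core clearly weakens growth inhibition. Compound 2 therefore stands at the highest number of the two, a modest distance from compound 1.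

Compound 3 `Nc1nc(Cl)c2ncn(Cc3ccccc3CCl)c2n1` differs from compound 2 by amino in place of hydrogen on an aromatic carbon, the amino sitting on the aromatic carbon between two ring nitrogen atoms, meta to a chloro group and meta and para to the fused ring. Among the measured compounds shown here, no measured step involves an amino group, so the expectation rests only on the change from compound 1 to compound 2, which shows that this carbon carries weight for potency. Filling it again with an amino group is expected to give a modest gain, a 3.1-fold lower number from compound 2 to compound 3 (0.49 log units; beyond the scatter), placing compound 3 at an estimated 5000 nM with a range of 1500 nM to 16000 nM.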

Compound 3, concentration for 50% growth inhibition: 5620 nM
Beside the measured number, compound 3's estimate is 1.1-fold (0.05 log units) below it; measured number inside the range.
By their numbers in this assay, from the lowest: compounds 1 and 3 (each within the scatter of the next); then compound 2.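

In this assay, amino on the aromatic carbon between two ring nitrogen atoms also gives stronger growth inhibition than hydrogen (a 2.8-fold lower number from compound 2 to compound 3 (0.44 log units; beyond the scatter)), so this gain is no longer tied to chloro alone. Amino and chloro on this carbon cannot be told apart by this measurement (a 1.7-fold higher number from compound 1 to compound 3 (0.23 log units; within the scatter)), which means that two quite different groups each do better than hydrogen here and neither can be ranked above the other. Nothing measured here explains why either group improves on hydrogen at this carbon.

The compounds shown leave open whether other groups on this carbon, such as methylamino, methoxy or hydroxyl, would go beyond the level reached by amino and chloro or fall back towards that of hydrogen. They also leave open how much the rest of the molecule contributes, since all three compounds keep the chloro group on the shared core and the chloromethyl group on the benzene ring, and swapping either for an amine or a methyl group would test that.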